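A few compounds are considered here, and "the series" means these few. Any claim that something is new, unique, unknown or untested is made for them only; others in the source may bear on it.

Compound 1 `COc1ccc(-n2ccnc2-c2cc(OC)c(OC)c(OC)c2)cc1[N+](=O)[O-]` gives 2500 nM in a functional assay on HeLa cells (Homo sapiens) for antiproliferative activity, read by MTT assay, with a stated time of 72 h; on this read-out higher numbers stand for weaker inhibition and lower numbers for stronger inhibition. Compound 2 `COc1ccc(-n2ccnc2-c2cc(OC)c(OC)c(OC)c2)cc1N` gives 80 nM in this assay. Compound 3 `COc1ccc(C(=O)Oc2cc(OC)c(OC)c(OC)c2)cc1[N+](=O)[O-]` reaches only a limit of the assay, > 100000 nM, in this assay.

Compound 1 and compound 2 share one core and differ at a single place: amino in place of nitro on an aromatic carbon. On that core the change produced a 31-fold lower number from compound 1 to compound 2 (1.49 log units; beyond the scatter). Compound 3 is built on a different core; how the two cores differ is not broken down here. Compound 4 `COc1ccc(C(=O)Oc2cc(OC)c(OC)c(OC)c2)cc1N` has not yet been measured. It stands to compound 3 exactly as compound 2 stands to compound 1: amino in place of nitro on an aromatic carbon. The surroundings of the place are the same word for word, so the change is the same one. The difficulty is the starting point: for compound 3 only the limit of > 100000 nM in this assay, at which 1 of the 3 values shown sits, is known, not a number, so the step cannot be pinned down. Compound 4 is expected to improve on compound 3 by about an at least 3.3-fold lower number from compound 3 to compound 4 (0.52 log units; beyond the scatter), resting on a 31-fold lower number from compound 1 to compound 2 (1.49 log units; beyond the scatter) seen on the other core. Compound 4 is therefore estimated at 30000 nM, most likely between 5000 nM and 200000 nM.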

Compound 4, half-maximal inhibitory concentration: > 100000 nM
Compound 4 gave a limit, no number; the forecaster's own chance of this, stated with the estimate: 40%; middle value at least 3.3-fold (0.52 log units) away from the limit.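

Compound 3 and compound 4 both reach only a limit of the assay in this assay, not a number, so the step between them cannot be read: the limit of > 100000 nM in this assay, at which 2 of the 4 values shown sit.

The compounds shown leave open whether amino in place of nitro on an aromatic carbon changes the activity at all on the core of compound 3.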